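The source may hold more compounds than are shown below. What is called first, only, known or untested is meant among the compounds shown, and "the series" means these compounds.

Measured compounds so far:
- compound 1 `O=C(O)c1ccc(-c2cccc(COc3ccc4c(c3)CN(C3CCCC3)C4=O)c2)c(Cl)c1` — in an ADME assay on a cell-free system (plasma, Rattus norvegicus) for metabolic stability, read by LC-MS, with a stated time of 1 h, at 37 degrees C, tested at 100 uM (a higher number here means that more of the compound is left, a lower number that less of the compound is left), compound 1 gives 100%
- compound 2 `O=C1c2ccc(OCc3cccc(-c4ccc(C(F)(F)F)cc4F)c3)cc2CN1C1CCCC1` — in this assay compound 2 gives "not determined" (no result reported)
- compound 3 `O=C1c2ccc(OCc3cccc(-c4ccc(Cl)cc4F)c3)cc2CN1C1CCCC1` — in this assay compound 3 gives "not determined" (no result reported)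

Compound 3 stands without a number: in this assay compound 3 is recorded only as "not determined" (no result reported), and compound 2, the other member of the series without a carboxylic acid, likewise has no result. For the measured compounds named here, the only number is that of compound 1, which in this assay gives 100%, that is, the whole of the compound is recovered after the stated time.

The next compound is compound 4 `O=C(O)c1ccc(Cl)c(-c2cccc(COc3ccc4c(c3)CN(C3CCCC3)C4=O)c2)c1`. Relative to compound 3 the change is 5-carboxy-2-chlorophenyl in place of 4-chloro-2-fluorophenyl on an aromatic carbon. Compound 4 thereby carries the same carboxy and chloro substitution as compound 1, only arranged differently on the outer ring, while the shared core is kept unchanged.

Going by the values given here, no step between measured compounds is available here. Since compound 3 has no number, no direction can be stated from it; the expectation for compound 4 rests on compound 1 alone. Because compound 1 gives 100% in this assay, a value near full recovery is expected for compound 4, and any deviation should stay within the usual scatter. Compound 4 is therefore estimated at 97%, with a range from 85% to 100%.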

Compound 4, percent of the compound remaining: 100%
Beside the measured number, compound 4's estimate is 3 percentage points below it; measured number inside the range.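

In this assay, for the compounds shown here, the exchange of 4-carboxy-2-chlorophenyl for 5-carboxy-2-chlorophenyl on an aromatic carbon shows no change at the digits printed from compound 1 to compound 4 (within the scatter), and this is the first comparison that can be read at all. It shows that, on the shared core, these two arrangements of the carboxy and chloro groups on the outer ring cannot be told apart in this read-out, with compound 4 at 100% and thus at full recovery, like compound 1, so the read-out leaves no room to show any gain between them. No measurement at hand gives a reason for this result.

Compound 3 has no number, so the step from it to compound 4 cannot be read, and the series gives no value for an outer ring lacking a carboxylic acid. From the compounds shown here alone, whether a methyl ester or a primary amide at the same place on the outer ring would also stay at full recovery in this assay remains open.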